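The source may hold more compounds than are shown below. What is called first, only, known or untested is meant among the compounds shown, and "the series" means these compounds.

Going by the values given here, compound 1 `Cn1c(-c2cccc(Cl)c2)nc2c(NC3CCCC3)ncnc21` is one of two compounds tested so far in an assay on CHO cells for displacement of a labelled ligand from adenosine receptor A3 (Homo sapiens), read by scintillation counting, with a stated time of 3 h (a lower number here means a stronger inhibitor, a higher number a weaker inhibitor), where compound 1 gives 514 nM. Its companion, compound 2 `CCn1c(-c2ccccc2)nc2c(NC3CCCC3)ncnc21`, gives 354 nM in this assay; compound 1 has the higher of the two numbers, but the gap between them lies within the scatter, so the two cannot be ranked. The next compound, compound 3 `COc1ccc(-c2nc3c(NC4CCCC4)ncnc3n2C)cc1`, differs from compound 1 in one place: 4-methoxyphenyl in place of 3-chlorophenyl on an aromatic carbon. Among the compounds with values here, no measured pair shows this change, so the step is open; compound 3 is expected to stay close to compound 1, with a step of a 1.3-fold lower number from compound 1 to compound 3 (0.11 log units; within the scatter) not beyond the scatter. Compound 3 is therefore estimated at 400 nM, within 100 nM to 1500 nM.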

Compound 3, inhibition constant: 1850 nM
Compound 3: middle estimate off by 4.6-fold (0.67 log units), on the low side; measured number above the stated range.
By their numbers in this assay, from the lowest: compounds 2 and 1 (each within the scatter of the next); then compound 3.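

At the aromatic carbon between two ring nitrogen atoms, the aryl group can't be swapped freely: in this assay, 4-methoxyphenyl in place of 3-chlorophenyl gives a 3.6-fold higher number from compound 1 to compound 3 (0.56 log units; beyond the scatter), a modest step beyond the scatter. Going by these compounds alone, compound 1 and compound 2 offered no single-place step, so this is the first readable change at this position, and nothing available explains it. The step changes both the substituent and where it sits on the phenyl ring, and the two cannot be separated here. As far as these compounds go, how 3-methoxyphenyl, 4-chlorophenyl or an amine would read in this place remains open.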